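The source may report more compounds than this note shows. Statements on the series, on what has been measured and on what is new or still open speak of the compounds shown alone.

Four compounds are compared here: compound 1 (`CC(=O)Oc1ccccc1C(=O)O[C@H]1CO[C@H]2[C@@H]1OC[C@H]2O`), compound 2 (`CC(=O)Oc1ccccc1C(=O)O[C@@H]1CO[C@H]2[C@@H]1OC[C@@H]2O`), compound 3 (`CC(=O)Oc1ccccc1C(=O)O[C@H]1CO[C@H]2[C@@H]1OC[C@H]2OC(=O)c1ccccc1O`) and compound 4 (`CC(=O)Oc1ccccc1C(=O)O[C@@H]1CO[C@H]2[C@@H]1OC[C@@H]2OC(=O)c1ccccc1O`). In an ADME assay on a cell-free system (plasma, Homo sapiens) for metabolic stability, at pH 7.4 (a lower number here means that the compound disappears faster, a higher number that the compound lasts longer), compound 1 gives 0.0542 h, compound 2 gives 0.0788 h and compound 3 gives 0.0817 h. These three values all lie within the scatter of one another, so compound 3 stands level with the other two.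

The move to compound 4 adds and removes nothing: the two compounds have the same atoms and bonds and differ only in configuration as drawn: 2 of 4 stereo elements differ; a stereocentre at a saturated ring carbon is drawn S in compound 3 and R in compound 4; a stereocentre at a saturated ring carbon is drawn R in compound 3 and S in compound 4. The closest guide is a 1.5-fold higher number from compound 1 to compound 2 (0.16 log units; within the scatter), which rests on the fact that compounds 1 and 2 differ only in the configuration as drawn and is the same kind of swap at two stereocentres, made without the (2-hydroxyphenyl)carbonyl group. The second guide is a 1.5-fold higher number from compound 1 to compound 3 (0.18 log units; within the scatter), where that group stands in place of hydrogen. Neither measured step leaves the scatter, so no real shift is expected in this assay. The expected change is a 1.1-fold higher number from compound 3 to compound 4 (0.04 log units; within the scatter). For compound 4 the estimated half-life is 0.09 h, with an expected range from 0.05 h to 0.17 h.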

Compound 4, half-life: 0.0702 h
Compound 4: the middle estimate sits 1.3-fold (0.11 log units) above what was measured; measured number inside the range.
By their numbers in this assay, from the lowest: compounds 1, 4, 2 and 3 (each within the scatter of the next).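

With the (2-hydroxyphenyl)carbonyl group in place, the swap at two stereocentres gives a 1.2-fold lower number from compound 3 to compound 4 (0.07 log units; within the scatter), so the configuration as drawn makes no readable difference in this assay on this larger compound either. Placing that group on the other configuration gives a 1.1-fold lower number from compound 2 to compound 4 (0.05 log units; within the scatter), so the change can now be read on two cores, and neither reading leaves the scatter: the same change on two cores in this assay, a 1.5-fold higher number (0.18 log units; within the scatter) from compound 1 to compound 3 and a 1.1-fold lower number (0.05 log units; within the scatter) from compound 2 to compound 4, 1.7-fold (0.23 log units) apart, within the scatter of two such steps Neither the swap nor this group therefore moves the half-life by a readable amount in these compounds.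

The compounds shown leave open whether a different group on that oxygen, such as a longer alkyl chain or one carrying an amine, would shift the half-life beyond the scatter. They also leave open what replacing the acetyl group shared by all four compounds would do.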